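Chain lengthening on the amine of the shared core

The compounds below may be only part of what the source reports. "The series", "measured", "known", "first", "only" and "open" are said of these compounds alone.

Compound 3 `CCNc1nnc(Cn2c(=O)oc3ccc(C)cc32)s1` stands highest of the three numbers in a functional assay on the whole organism for inhibition, with Mus musculus as the target, read by paw edema, with a stated time of 180 min, at a dose of 200 mg/kg by the oral route; a lower number here means a weaker effect, a higher number a stronger effect of the compound at the dose given: compound 3 gives 71.3%. Compound 1 `CNc1nnc(Cn2c(=O)oc3ccc(C)cc32)s1` gives 46.9%, and compound 2 `CCCn1c(Cn2c(=O)oc3ccc(C)cc32)n[nH]c1=S` gives 44.3%; both lie beyond the scatter below compound 3. Compound 4 `CCCNc1nnc(Cn2c(=O)oc3ccc(C)cc32)s1` is not yet measured; its change from compound 3 is methyl in place of hydrogen on a saturated chain carbon, two bonds along the chain from a nitrogen on an aromatic ring. Among the measured compounds shown here, the one measured step that bears on it is a number 24.4 percentage points higher from compound 1 to compound 3 (beyond the scatter), the same kind of lengthening one bond nearer the ring. A second lengthening is therefore expected to move in the same direction but by less, the read-out being a percentage with limited room above the number of compound 3. Compound 4 is expected at 76%, within 60% to 88%, a step of a number 4.7 percentage points higher from compound 3 to compound 4 (within the scatter).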

Compound 4, a percentage reported as inhibition, in the whole organism at one dose (the size of the read-out at that dose, not a potency): 39.4%
Estimate against measurement, compound 4: 36.6 percentage points above; the measured number lies below the stated range.
By their numbers in this assay, from the lowest: compounds 4, 2 and 1 (each within the scatter of the next); then compound 3.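

In this assay the added methyl on a saturated chain carbon, two bonds along the chain from a nitrogen on an aromatic ring, brings no further gain, and chain length on this amine does not act in one direction: the result is a number 31.9 percentage points lower from compound 3 to compound 4 (beyond the scatter) for ethylamino to propylamino. Ethyl in place of hydrogen on the saturated chain carbon bound to that nitrogen gives a number 7.5 percentage points lower from compound 1 to compound 4 (within the scatter) and so no readable change, which leaves compound 3 alone at the top among these chains. Open, on these data alone, is whether a butyl or isopropyl chain on the same amine would stay as low as compound 4. Nothing available gives a reason for this drop.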